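A few compounds are considered here, and "the series" means these few. Any claim that something is new, unique, unknown or untested is made for them only; others in the source may bear on it.

In a functional assay on MCF7 cells (Homo sapiens) for inhibition, with a stated time of 48 h (on this read-out higher numbers stand for weaker inhibition and lower numbers for stronger inhibition), three compounds with a shared core have been measured. Compound 1 `COc1cc(Sc2c[nH]c3ccc(F)cc23)cc(OC)c1OC`, which carries fluoro, gives 160 nM. Compound 2 `COc1ccc2[nH]cc(Sc3cc(OC)c(OC)c(OC)c3)c2c1`, with methoxy instead, gives 22 nM, and compound 3 `CCOc1ccc2[nH]cc(Sc3cc(OC)c(OC)c(OC)c3)c2c1`, with ethoxy, gives 16 nM. Compound 3 therefore shares the low end of these numbers with compound 2, well apart from compound 1.

Compound 4 `COc1cc(Sc2c[nH]c3ccc(OC(C)C)cc23)cc(OC)c1OC` turns ethoxy into isopropoxy: methyl in place of hydrogen on a saturated chain carbon bound to an oxygen on an aromatic ring and a saturated chain carbon. In plain terms, this puts methyl in place of hydrogen on a saturated chain carbon bound to an oxygen on an aromatic ring and a saturated chain carbon.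

Among the compounds with values here, the closest precedent is the similar methyl addition in a 1.4-fold lower number from compound 2 to compound 3 (0.14 log units; within the scatter). The larger steps away from fluoro, a 7.3-fold lower number from compound 1 to compound 2 (0.86 log units; beyond the scatter) and a 10-fold lower number from compound 1 to compound 3 (1.00 log units; beyond the scatter), are a different kind of change and bear on this one only loosely. Within the data shown here, no measured compound has a branched chain here, so the expectation is uncertain, but no step beyond the scatter is expected in this assay. The estimated step is a 1.4-fold higher number from compound 3 to compound 4 (0.14 log units; within the scatter). Compound 4 is expected at 22 nM, with an estimated range of 8 nM to 60 nM.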

Compound 4, half-maximal inhibitory concentration: 1500 nM
The estimate for compound 4 lay 68-fold (1.83 log units) below the measured number; measured number above the stated range.
By their numbers in this assay, from the lowest: compounds 3 and 2 (each within the scatter of the next); then compound 1; then compound 4.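

In this assay, within the data shown here, this position tolerates less on the oxygen than the earlier compounds showed: compound 2 and compound 3 lie within the scatter of each other, yet turning ethoxy into isopropoxy gives a 94-fold higher number from compound 3 to compound 4 (1.97 log units; beyond the scatter). Isopropyl in place of methyl on the oxygen gives a 68-fold higher number from compound 2 to compound 4 (1.83 log units; beyond the scatter), and isopropoxy in place of fluoro gives a 9.4-fold higher number from compound 1 to compound 4 (0.97 log units; beyond the scatter), so compound 4 goes against the pattern of compound 2 and compound 3, whose oxygen-linked chains gave lower numbers than fluoro. Nothing available explains this jump.

Going by these compounds, it remains open whether the loss follows the branch itself or simply the added carbon, a question that a straight propoxy chain could help settle. Also open, on these data alone, is how a cyclopropoxy group, which ties the branch into a ring, would fit at this position.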